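The source may hold more compounds than are shown below. What is called first, only, known or untested is meant among the compounds shown, and "the series" means these compounds.

In a functional assay (mitochondria) for inhibition, with Rattus norvegicus as the target (on this read-out lower numbers stand for stronger inhibition and higher numbers for weaker inhibition), compound 1 (`Cc1cccc(C)c1NC(=O)CN1CCN(CC(O)COc2ccc3oc(-c4ccccc4)nc3c2)CC1`) gives 23000 nM and compound 2 (`Cc1cccc(C)c1NC(=O)CN1CCN(CC(O)COc2ccc3oc(-c4ccc(C(F)(F)F)cc4)nc3c2)CC1`) gives 8000 nM as the lower of the two numbers. Compound 3 (`Cc1cccc(C)c1NC(=O)CN1CCN(CC(O)COc2ccc3oc(-c4cccc(C(F)(F)F)c4)nc3c2)CC1`) differs from compound 2 in one place (3-(trifluoromethyl)phenyl in place of 4-(trifluoromethyl)phenyl on an aromatic carbon) with 3-(trifluoromethyl)phenyl in place of 4-(trifluoromethyl)phenyl on an aromatic carbon. For the measured compounds named here, the one measured step that bears on this is modest (a 2.9-fold lower number from compound 1 to compound 2 (0.46 log units; beyond the scatter)) and it introduces the trifluoromethyl group rather than moving it. A step no larger is therefore expected in this assay, probably none beyond the scatter, with the direction open. The estimated change (a 1.3-fold higher number from compound 2 to compound 3 (0.10 log units; within the scatter)) is small. The estimated value for compound 3 is 10000 nM (4000 nM to 25000 nM).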

Compound 3, half-maximal inhibitory concentration: 13000 nM
Estimate against measurement, compound 3: 1.3-fold (0.11 log units) below; the range from low to high includes it.
By their numbers in this assay, from the lowest: compounds 2, 3 and 1 (each within the scatter of the next, the first and the last beyond it).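

Moving the trifluoromethyl group gives a 1.6-fold higher number from compound 2 to compound 3 (0.21 log units; within the scatter) so that in this assay the 3-(trifluoromethyl)phenyl and 4-(trifluoromethyl)phenyl groups cannot be told apart. Putting trifluoromethyl on the phenyl of compound 1 to reach the 3-(trifluoromethyl)phenyl group gives a 1.8-fold lower number from compound 1 to compound 3 (0.25 log units; within the scatter) so this placement cannot be told apart from the parent either. The only step beyond the scatter among these three compounds remains a 2.9-fold lower number from compound 1 to compound 2 (0.46 log units; beyond the scatter) and compound 3 falls within the scatter of both neighbours.

Nothing available here explains these numbers. From the compounds shown here alone, whether an amine or a carboxylic acid in place of trifluoromethyl on this phenyl ring would move the number beyond the scatter stays open.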